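Bromo in place of fluoro: compound 2 to compound 3

This account rests on a few compounds, and the source may have more. Where it says the series, first, only, none or still open, it means among the compounds named here.

Among the compounds with values here, compound 2 `Cc1nn(-c2ccccc2F)c2c1C(c1ccc(Oc3ccccc3)cc1)SC(C)C(=O)N2` gives 3900 nM in an assay on isolated protein for agonist activity at Bile acid receptor (Homo sapiens), read by AlphaScreen, with a stated time of 30 min (a higher number here means that more compound is needed for the effect, a lower number that less compound is needed), the highest of the two numbers so far. Compound 1 `Cc1nn(-c2ccccc2C(F)(F)F)c2c1C(c1ccc(Oc3ccccc3)cc1)SC(C)C(=O)N2` gives 2000 nM in this assay, and the step of a 2.0-fold higher number from compound 1 to compound 2 (0.29 log units; within the scatter) stays within the scatter. Compound 3 `Cc1nn(-c2ccccc2Br)c2c1C(c1ccc(Oc3ccccc3)cc1)SC(C)C(=O)N2` differs from compound 2 by bromo in place of fluoro on an aromatic carbon. Within the data shown here, only one step bears on this place, a 2.0-fold higher number from compound 1 to compound 2 (0.29 log units; within the scatter), and it swapped one halogen-bearing group for another without leaving the scatter; no measured step involves bromo. A step no larger than the scatter is therefore expected, a 1.6-fold lower number from compound 2 to compound 3 (0.19 log units; within the scatter). Compound 3 is expected to give about 2500 nM, between 900 nM and 7000 nM.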

Compound 3, half-maximal effective concentration: 1800 nM
Estimate against measurement, compound 3: 1.4-fold (0.14 log units) above, and the stated range covers the measured number.
By their numbers in this assay, from the lowest: compounds 3, 1 and 2 (each within the scatter of the next, the first and the last beyond it).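

In this assay, within the data shown here, the change from 2-fluorophenyl to 2-bromophenyl gives the only step at this position that lies beyond the scatter, a 2.2-fold lower number from compound 2 to compound 3 (0.34 log units; beyond the scatter), and it is modest. Bromo and trifluoromethyl cannot be told apart here, a 1.1-fold lower number from compound 1 to compound 3 (0.05 log units; within the scatter), so the only separation among these three groups is between bromo and fluoro. No measurement shown accounts for this separation. Still open, on these data alone, is how an amine or a methoxy group at this place would read. Also open, as far as these compounds go, is whether the unsubstituted phenyl would differ from these three.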